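From 4-bromophenyl to 3-chlorophenyl on an amide-type nitrogen

The compounds below may be only part of what the source reports. "The series", "measured", "known", "first", "only" and "open" are said of these compounds alone.

In a functional assay on SGC-7901 cells (Homo sapiens) for antiproliferative activity, read by sulforhodamine B assay, with a stated time of 72 h (a higher number here means a weaker inhibitor, a lower number a stronger inhibitor), compound 3 `S=C(N/N=C/c1ccc2ccccc2n1)Nc1ccc(Br)cc1` gives 69400 nM, within the scatter of compound 2 `S=C(NCc1ccccc1)N/N=C/c1ccc2ccccc2n1` at 53700 nM. Compound 1 `Fc1ccccc1NC(=S)N/N=C/c1ccc2ccccc2n1` gives > 100000 nM, which is a limit of the assay and not a number. Compound 4 `S=C(N/N=C/c1ccc2ccccc2n1)Nc1cccc(Cl)c1` differs from compound 3 in one place: 3-chlorophenyl in place of 4-bromophenyl on an amide-type nitrogen. Three measured steps at this same nitrogen bear on the change. The floors of an at least 1.8-fold lower number from compound 1 to compound 2 (0.27 log units; that floor lies within the scatter) and an at least 1.4-fold lower number from compound 1 to compound 3 (0.15 log units; that floor lies within the scatter) lie within the scatter, and a 1.3-fold higher number from compound 2 to compound 3 (0.11 log units; within the scatter) is also within it. On that basis, no step beyond the scatter is expected in this assay. The expected change is a 1.0-fold higher number from compound 3 to compound 4 (0.00 log units; within the scatter). Compound 4 is estimated at 70000 nM, with an expected range of 35000 nM to 100000 nM.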

Compound 4, half-maximal inhibitory concentration: 61300 nM
Compound 4: middle estimate off by 1.1-fold (0.06 log units), on the high side, and the stated range covers the measured number.
By their numbers in this assay, from the lowest: compounds 2, 4 and 3 (each within the scatter of the next). At a limit, above all of these: compound 1.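

In this assay, replacing 4-bromophenyl with 3-chlorophenyl gives a 1.1-fold lower number from compound 3 to compound 4 (0.05 log units; within the scatter), and replacing benzyl with 3-chlorophenyl gives a 1.1-fold higher number from compound 2 to compound 4 (0.06 log units; within the scatter). Compound 2, compound 3 and compound 4 thus form a set of three groups on this nitrogen with no step beyond the scatter. Compound 1 carries a limit and not a number: the limit of > 100000 nM in this assay, at which 1 of the 4 values shown sits. Replacing 2-fluorophenyl with 3-chlorophenyl therefore gives only a floor, an at least 1.6-fold lower number from compound 1 to compound 4 (0.21 log units; that floor lies within the scatter).

On these data alone, whether an amine, a carboxylic acid or a longer chain on this nitrogen would shift the number beyond the scatter remains open.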